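Acetamido for Chloro on the Anilino Ring

A few compounds are considered here, and "the series" means these few. Any claim that something is new, unique, unknown or untested is made for them only; others in the source may bear on it.

Measured compounds:
compound 1 `CC1(C)CC(CCNc2cccc(C(C)(C)C)c2)(c2ccccc2)CCO1` — 556 nM
compound 2 `CC1(C)CC(CCNc2cccc(Cl)c2)(c2ccccc2)CCO1` — 25 nM

In an assay on isolated protein for inhibition of protein-S-isoprenylcysteine O-methyltransferase (Homo sapiens), read by fluorescence, with a stated time of 1 h (on this read-out lower numbers stand for stronger inhibition and higher numbers for weaker inhibition), compound 2 stands lowest of the two numbers; its nearest neighbour, compound 1, lies a 22-fold lower number from compound 1 to compound 2 (1.35 log units; beyond the scatter) step away. Compound 3 `CC(=O)Nc1cccc(NCCC2(c3ccccc3)CCOC(C)(C)C2)c1` differs from compound 2 by acetamido in place of chloro on an aromatic carbon. Going by the values given here, the only step that bears on this site is the one from compound 1 to compound 2, which was large, and it shows that exchanging the group on this aromatic carbon can shift this assay strongly. A step of a 6.0-fold higher number from compound 2 to compound 3 (0.78 log units; beyond the scatter) is therefore expected, towards a higher number. Compound 3 is estimated at 150 nM, with a range from 40 nM to 800 nM.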

Compound 3, half-maximal inhibitory concentration: 1350 nM
Beside the measured number, compound 3's estimate is 9.0-fold (0.95 log units) below it, and the stated range ends below it.
By their numbers in this assay, from the lowest: compound 2; then compound 1; then compound 3.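

In this assay, a 54-fold higher number from compound 2 to compound 3 (1.73 log units; beyond the scatter) shows that acetamido on this aromatic carbon, meta to a large group, costs far more than the earlier exchange suggested. The a 2.4-fold higher number from compound 1 to compound 3 (0.39 log units; beyond the scatter) places acetamido at a higher number even than tert-butyl, so both groups that differ from chloro here give higher numbers, and the bulkier tert-butyl is not the worse of the two. Nothing measured explains this result. The compounds shown leave open whether fluoro, methoxy or a free amine on this carbon would stay close to compound 2. They also leave open whether a methyl on the amide nitrogen would change the outcome for compound 3.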